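Permeability on Exchanging an Aryl Ether for Neopentyl Ether

A few compounds are considered here, and "the series" means these few. Any claim that something is new, unique, unknown or untested is made for them only; others in the source may bear on it.

Compound 2 `CCS(=O)(=O)Nc1ccc(Oc2ccc(C(F)(F)F)cc2)c(-c2cn(C)c(=O)c3[nH]ccc23)c1` gives 11 10^-6 cm/s in an ADME assay on MDCK cells (Canis lupus familiaris) for permeability (on this read-out higher numbers stand for higher permeability and lower numbers for lower permeability), and stands level with compound 1 `CCS(=O)(=O)Nc1ccc(Oc2ccc(C#N)cc2)c(-c2cn(C)c(=O)c3[nH]ccc23)c1`, which gives 11 10^-6 cm/s in this assay; the step of no change at the digits printed from compound 1 to compound 2 (within the scatter) lies within the scatter. Compound 3 `CCS(=O)(=O)Nc1ccc(OCC(C)(C)C)c(-c2cn(C)c(=O)c3[nH]ccc23)c1` differs from compound 2 by neopentyl in place of 4-(trifluoromethyl)phenyl on an oxygen on an aromatic ring. Among the compounds with values here, no measured step exchanges a ring for a chain on that oxygen, and the single measured step only swaps one group on the aromatic ring without moving the read-out. Compound 3 is therefore expected to stay close, with a 1.1-fold higher number from compound 2 to compound 3 (0.04 log units; within the scatter). The estimate for compound 3 is 12 10^-6 cm/s, ranging from 6 10^-6 cm/s to 24 10^-6 cm/s.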

Compound 3, apparent permeability: 43 10^-6 cm/s
Compound 3: middle estimate off by 3.6-fold (0.55 log units), on the low side, and the stated range ends below it.
By their numbers in this assay, from the lowest: compounds 1 and 2 (each within the scatter of the next); then compound 3.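

Neopentyl in place of 4-(trifluoromethyl)phenyl gives a 3.9-fold higher number from compound 2 to compound 3 (0.59 log units; beyond the scatter) in this assay and neopentyl in place of 4-cyanophenyl gives a 3.9-fold higher number from compound 1 to compound 3 (0.59 log units; beyond the scatter) on the same oxygen. The read-out therefore responds to exchanging the whole aromatic ring for a chain at this position, whereas swapping the group carried on that ring had left it unmoved. Nothing measured here explains the rise. On these data alone, whether it belongs to neopentyl alone remains open, as a shorter ethyl chain or a saturated cyclohexyl ring on that oxygen would be needed to separate the loss of the aromatic ring from the shape of the chain.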